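Cytotoxicity of Amide Analogues: From Compound 2 to Compound 4

The source may hold more compounds than are shown below. What is called first, only, known or untested is meant among the compounds shown, and "the series" means these compounds.

Compound 1 is `Cc1ccc(NC(=O)c2cccc(/C=C3\CC(=O)N(c4ccccc4)C3=O)c2)cc1`. In an ADME assay on NCM460 cells (Homo sapiens) for cytotoxicity, read by MTT assay, with a stated time of 72 h (on this read-out lower numbers stand for stronger inhibition and higher numbers for weaker inhibition), compound 1 reaches only the limit of > 100000 nM.
Compound 2 is `CCCCCN1C(=O)C/C(=C\c2cccc(C(=O)Nc3ccc(C)cc3)c2)C1=O`. In this assay compound 2 likewise reaches only the limit of > 100000 nM.
Compound 3 is `O=C(Nc1ccc(OC(F)F)cc1)c1cccc(/C=C2\CC(=O)N(c3ccccc3)C2=O)c1`. In this assay compound 3 also reaches only the limit of > 100000 nM.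

Compound 2 therefore stands where every measured member of the series stands: at the limit of the assay, not at a number, as the limit of > 100000 nM in this assay, at which 3 of the 3 values shown sit, makes plain. The step from compound 1 to compound 2, a step that the two limits leave unreadable from compound 1 to compound 2, replaces phenyl with pentyl on the amide-type nitrogen in the ring, and the step from compound 1 to compound 3, a step that the two limits leave unreadable from compound 1 to compound 3, puts difluoromethoxy in place of methyl on an aromatic carbon; neither can be read in size, since both ends sit at the limit.

Compound 4 is `CCCCCN1C(=O)C/C(=C\c2cccc(C(=O)Nc3cccc(F)c3)c2)C1=O`. It differs from compound 2 by 3-fluorophenyl in place of 4-methylphenyl on an amide-type nitrogen. Among the measured compounds shown here, the two measured steps bear on it only in showing that changes at two other positions left the read-out at the limit; no step in this assay is readable in direction or size. Compound 4 is therefore expected to remain at the limit, with an estimated step that the limit leaves unreadable from compound 2 to compound 4. Compound 4 is estimated at 200000 nM, within 100000 nM to 1000000 nM.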

Compound 4, half-maximal inhibitory concentration: > 100000 nM
Compound 4 gave a limit, no number; the forecaster's own chance of this, stated with the estimate: 85%; the middle value lies beyond the limit too.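

Compound 2 and compound 4 both give only a limit, so the change to 3-fluorophenyl in place of 4-methylphenyl cannot be read in direction or size. The series remains where it stood: the limit of > 100000 nM in this assay, at which 4 of the 4 values shown sit. The compounds shown leave open whether this assay would give an actual number for any of them.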